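Fluoro to Amino on One Aromatic Carbon

The source may report more compounds than this note shows. Statements on the series, on what has been measured and on what is new or still open speak of the compounds shown alone.

In a functional assay on HeLa cells (Homo sapiens) for inhibition, with a stated time of 48 h, tested at 50 uM (on this read-out higher numbers stand for more inhibition of growth at the one concentration tested and lower numbers for less inhibition of growth), compound 1 `COc1ccccc1/C=C/[C@@](C)(/C=C/c1ccc(O)cc1)CCC=C(C)C` gives 50%, compound 2 `COc1ccc(/C=C/[C@@](C)(/C=C/c2ccc(O)cc2)CCC=C(C)C)cc1` gives 20% and compound 3 `CC(C)=CCC[C@](C)(/C=C/c1ccc(O)cc1)/C=C/c1ccc(F)cc1` gives 43%. Compound 3 thus lies within the scatter of compound 1 and clearly above compound 2. Compound 4 `CC(C)=CCC[C@@](C)(/C=C/c1ccc(N)cc1)/C=C/c1ccc(O)cc1` differs from compound 3 by amino in place of fluoro on an aromatic carbon. The closest guide is a number 23 percentage points higher from compound 2 to compound 3 (beyond the scatter), a modest step made at this same place, while a number 7 percentage points lower from compound 1 to compound 3 (within the scatter) stays within the scatter. For the measured compounds named here, no measured compound carries amino, so the direction is uncertain. The expected step, a number 8 percentage points lower from compound 3 to compound 4 (within the scatter), is small and would stay within the scatter. For compound 4 the estimate is 35%, with an expected range of 15% to 52%.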

Compound 4, percent growth inhibition at one concentration: 27%
Beside the measured number, compound 4's estimate is 8 percentage points above it; measured number inside the range.
By their numbers in this assay, from the lowest: compounds 2 and 4 (each within the scatter of the next); then compounds 3 and 1 (each within the scatter of the next).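

Amino in place of fluoro on this aromatic carbon gives a number 16 percentage points lower from compound 3 to compound 4 (beyond the scatter) and so shows that this position responds to a change other than the earlier swap of methoxy for fluoro. Amino in place of methoxy gives a number 7 percentage points higher from compound 2 to compound 4 (within the scatter) and leaves those two groups level on this read-out, while 4-aminophenyl in place of 2-methoxyphenyl gives a number 23 percentage points lower from compound 1 to compound 4 (beyond the scatter) and leaves compound 4 clearly under compound 1. No measurement shown here explains these differences.

Where a dimethylamino group or a carboxylic acid on this same aromatic carbon would fall remains open. So does whether amino would behave alike on the ring carbon that holds methoxy in compound 1.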